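Replacing Dimethylamino with Fluoro, Starting from a Limit

The source may hold more compounds than are shown below. What is called first, only, known or untested is meant among the compounds shown, and "the series" means these compounds.

In a physicochemical assay for solubility, read by nephelometry (on this read-out higher numbers stand for higher solubility and lower numbers for lower solubility), compound 2 `CN(C)c1cc(CN2C(=O)N(c3ccc(SC(F)(F)F)cc3)C(=O)C2(C)C)ccn1` gives < 0.022 ug/mL, which is a limit of the assay and not a number. Compound 1 `CN1CCN(c2cc(CN3C(=O)N(c4ccc(SC(F)(F)F)cc4)C(=O)C3(C)C)ccn2)CC1` gives 0.159 ug/mL. Among the measured compounds shown here, the one measured step, an at least 7.2-fold lower number from compound 1 to compound 2 (0.85 log units; beyond the scatter), lies beyond the scatter and also swaps a group on an aromatic carbon, though no fluoro is involved. Compound 3 `CC1(C)C(=O)N(c2ccc(SC(F)(F)F)cc2)C(=O)N1Cc1ccnc(F)c1` carries fluoro in place of dimethylamino on an aromatic carbon. For the measured compounds named here, with only that step as a guide, no change beyond the scatter is expected in this assay, and the expected step is an at least 1.3-fold higher number from compound 2 to compound 3 (0.13 log units; that floor lies within the scatter). Compound 3 is estimated at 0.03 ug/mL, within an expected range of 0.012 ug/mL to 0.12 ug/mL.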

Compound 3, solubility: 0.032 ug/mL
Beside the measured number, compound 3's estimate is 1.1-fold (0.03 log units) below it, within the range that was stated.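

In this assay, putting fluoro in place of dimethylamino next to the ring nitrogen gives an at least 1.4-fold higher number from compound 2 to compound 3 (0.16 log units; that floor lies within the scatter), so no gain can be claimed from this change. For compound 2 the reading is a limit of the assay and not a number: the limit of < 0.022 ug/mL in this assay, at which 1 of the 3 values shown sits. Fluoro, like dimethylamino, stays short of 4-methylpiperazin-1-yl, with a 5.0-fold lower number from compound 1 to compound 3 (0.70 log units; beyond the scatter), so among these groups the highest reading at this position still belongs to the 4-methylpiperazin-1-yl group.

On these data alone, whether a morpholine or a carboxylic acid in the same place would reach that reading stays open. Also open, as far as these compounds go, is where compound 2 truly lies relative to compound 3.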